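The source may hold more compounds than are shown below. What is called first, only, known or untested is meant among the compounds shown, and "the series" means these compounds.

Compound 1 `COC(=O)c1cc(CNc2cc(OC)c(OC)c(OC)c2)ccc1OC` is the reference point of this note. In a functional assay on HCT-116 cells (Homo sapiens) for inhibition, read by MTT assay, with a stated time of 48 h (on this read-out lower numbers stand for stronger inhibition and higher numbers for weaker inhibition), compound 1 gives 38100 nM, the highest of the two numbers in hand. For the measured compounds named here, the only other measured member, compound 2 `COc1ccc(CN(C(=O)C[Se]C#N)c2cc(OC)c(OC)c(OC)c2)cc1O`, gives 310 nM in this assay, a far lower number and beyond the scatter; the two structures differ in several places at once, so no single step is drawn between them and the gap cannot be assigned to any one change. Compound 3 `COc1ccc(CNc2cc(OC)c(OC)c(OC)c2)cc1N` remains to be measured. It differs from compound 1 in one place: amino in place of methoxycarbonyl on an aromatic carbon. The exchange sits on an aromatic carbon of a six-membered aromatic ring of carbon only, ortho to a methoxy group and meta to a large group. Going by the values given here, no measured pair isolates this exchange, so its direction is open. For compound 3 the expectation in this assay is a small step toward a lower number, a 1.9-fold lower number from compound 1 to compound 3 (0.28 log units; within the scatter), not clearly beyond the scatter. Compound 3 is accordingly estimated at 20000 nM, within a range of 5000 nM to 80000 nM.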

Compound 3, half-maximal inhibitory concentration: 8270 nM
For compound 3 the middle estimate is 2.4-fold (0.38 log units) above the measured one, and the stated range covers the measured number.
By their numbers in this assay, from the lowest: compound 2; then compound 3; then compound 1.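

In this assay, the aromatic carbon ortho to a methoxy group and meta to a large group now has one exchange read on its own: a 4.6-fold lower number from compound 1 to compound 3 (0.66 log units; beyond the scatter) with amino in place of methoxycarbonyl, a modest step beyond the scatter. For the compounds shown here, the direction of this exchange, open while no measured pair isolated it, is therefore toward stronger inhibition. At this position, replacing a group of 4 heavy atoms and 2 hydrogen-bond acceptors with amino, which has 1 heavy atom and brings 1 hydrogen-bond donor, does not weaken inhibition, although nothing on hand gives a reason for the step.

Going by these compounds alone, the single pair cannot separate what the amino adds from what is lost with the methoxycarbonyl, and a compound with plain hydrogen on this carbon would be needed to divide the step between the two groups. The compounds shown also leave open how a carboxylic acid, a carboxamide, a nitro group or an acetylated amine on the same carbon would read, and whether the step holds on any core other than that of compound 1.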